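This account rests on a few compounds, and the source may have more. Where it says the series, first, only, none or still open, it means among the compounds named here.

Compound 1 `CC1(C)Oc2ccc(C#N)cc2[C@@H](N2CCCC2=O)[C@]1(C)O`: 4000 nM
Compound 2 `CC1(C)Oc2ccc(C#N)cc2[C@@H](OC2=CC(=O)CC2)[C@]1(C)O`: 20 nM
Compound 3 `CC1(C)Oc2ccc(C#N)cc2[C@@H](Oc2ccc(=O)[nH]n2)[C@]1(C)O`: 6 nM

These three compounds share one core and differ in a single group, and all were tested in a functional assay for inhibition, with Sus scrofa as the target; a lower number here means a stronger inhibitor, a higher number a weaker inhibitor. Compound 3 stands lowest at 6 nM, which makes it the strongest inhibitor of the three. The nearest gap is a 3.3-fold lower number from compound 2 to compound 3 (0.52 log units; beyond the scatter), and the furthest is a 670-fold lower number from compound 1 to compound 3 (2.82 log units; beyond the scatter).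

Compound 4 `CC1(C)Oc2ccc(C#N)cc2[C@@H](n2nc(N)ccc2=O)[C@]1(C)O` keeps the core and changes only the group on a saturated ring carbon, next to the ring atom that bears a hydroxy group: a group of 8 heavy atoms (4 carbon, 3 nitrogen, 1 oxygen; one six-membered aromatic ring with 2 hetero atoms) in place of a group of 8 heavy atoms (4 carbon, 2 nitrogen, 2 oxygen; one six-membered aromatic ring with 2 hetero atoms), on a saturated ring carbon. Compound 4 carries this group through a ring nitrogen, as compound 1 does, whereas compounds 2 and 3 carry theirs on an oxygen.

Among the measured compounds shown here, two measured steps bear on this change. The large step of a 200-fold lower number from compound 1 to compound 2 (2.30 log units; beyond the scatter) accompanies a move from a nitrogen to an oxygen, although the ring changes too. The modest step of a 3.3-fold lower number from compound 2 to compound 3 (0.52 log units; beyond the scatter) shows a smaller shift between two groups both held on oxygen. For the measured compounds named here, no measured compound carries the entering ring, and compound 1 is the only nitrogen-held example, so the evidence is thin.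

A moderate move towards weaker inhibition in this assay is therefore expected, with the estimated step being a 6.7-fold higher number from compound 3 to compound 4 (0.82 log units; beyond the scatter). The estimate for compound 4 is 40 nM, with an expected range from 6 nM to 300 nM.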

Compound 4, half-maximal inhibitory concentration: 40000 nM
Compound 4: the middle estimate sits 1000-fold (3.00 log units) below what was measured, and the stated range ends below it.
By their numbers in this assay, from the lowest: compound 3; then compound 2; then compound 1; then compound 4.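

In this assay, among the compounds shown here, the change on this saturated ring carbon proves far larger than the earlier steps showed, although both groups hold a six-membered aromatic ring with 2 hetero atoms: a 6700-fold higher number from compound 3 to compound 4 (3.82 log units; beyond the scatter). The step of a 2000-fold higher number from compound 2 to compound 4 (3.30 log units; beyond the scatter) is also large, so the four compounds now fall into two sets, with the oxygen-held groups of compound 2 and compound 3 giving the lowest numbers and the ring-nitrogen-held groups of compound 1 and compound 4 the highest, and none of the four goes against this. An aromatic ring held through nitrogen therefore gives no gain over the non-aromatic ring of compound 1, as the step of a 10-fold higher number from compound 1 to compound 4 (1.00 log units; beyond the scatter) runs towards weaker inhibition.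

Compound 3 and compound 4 differ in both the attaching atom and the ring, so the shift cannot be assigned to either alone, and a matched pair, such as the ring of compound 3 held through nitrogen or an amine on the oxygen-held ring, would be needed to separate them, while a simple methoxy group on this carbon would show how much any ring contributes. Nothing measured alongside these values accounts for the size of the step.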